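This account rests on a few compounds, and the source may have more. Where it says the series, first, only, none or still open, it means among the compounds named here.

Within the data shown here, compound 1 `Cc1cc(C)c(CN2CCc3c(Cl)cc([C@@H](CO)[C@@H]4CCOC4)c(Cl)c3C2=O)c(=O)[nH]1` is the only compound in this set with a single number in a functional assay on KARPAS-422 cells (Homo sapiens) for antiproliferative activity, read by resazurin assay, with a stated time of 72 h; a lower number here means a stronger inhibitor, a higher number a weaker inhibitor: there compound 1 gives 3950 nM. Compound 2 `COC(c1cc(Cl)c2c(c1Cl)C(=O)N(Cc1c(C)cc(C)[nH]c1=O)CC2)C1CCN(C2COC2)CC1` stands beside it with entries that do not agree among themselves; in this assay compound 2 gives 2260 nM; 25 nM (2 entries), and the several entries of compound 2 in this assay, 2260 nM; 25 nM (2 entries) shows how far apart those entries lie, so compound 2 offers no firm anchor. Among the measured compounds shown here, no step between two measured compounds is available here. Compound 3 `Cc1cc(C)c(CN2CCc3c(Cl)cc([C@H](CO)[C@@H]4CCCO4)c(Cl)c3C2=O)c(=O)[nH]1` is the next compound, and it differs from compound 1 by a group of 8 heavy atoms (6 carbon, 2 oxygen; one five-membered non-aromatic ring with 1 hetero atom) in place of a group of 8 heavy atoms (6 carbon, 2 oxygen; one five-membered non-aromatic ring with 1 hetero atom), on an aromatic carbon. The two compounds carry the same atoms joined differently, the change sitting on an aromatic carbon of the shared core, ortho to a chloro group and meta to a chloro group, meta to a fused ring and para to a fused ring. For the measured compounds named here, with no measured step of this kind to lean on, the expectation is that the shift in this assay stays within the scatter, with no direction favoured, so compound 3 is expected at 3000 nM, between 800 nM and 12000 nM. The step that this estimate means is expected to be a 1.3-fold lower number from compound 1 to compound 3 (0.12 log units; within the scatter).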

Compound 3, half-maximal inhibitory concentration: 57 nM
Estimate against measurement, compound 3: 53-fold (1.72 log units) above; measured number outside the range, below it.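

Before this pair, no step at this position could be read; now the aromatic carbon ortho to a chloro group and meta to a chloro group proves highly sensitive to how the group on it is joined. Rearranging the same atoms, with no change in the heavy-atom count or in the counts of hydrogen-bond donors and acceptors, gives a 69-fold lower number from compound 1 to compound 3 (1.84 log units; beyond the scatter) in this assay, so composition alone does not set the activity of these compounds at this position. Nothing measured here accounts for the size of this step.

The pair cannot separate the effect of where the five-membered non-aromatic ring is attached from that of the spatial arrangement at the defined stereocentres, since the two compounds may differ in both and the other stereoisomers of each group are not among the compounds shown. Going by these compounds, it also remains open whether the activity of compound 3 would persist with an amine or a carboxylic acid in place of the hydroxyl group, or with a six-membered non-aromatic ring in place of the five-membered one.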